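The compounds below may be only part of what the source reports. "The series", "measured", "known", "first", "only" and "open" are said of these compounds alone.

Measured in a functional assay on A549 cells (Homo sapiens) for inhibition, read by sulforhodamine B assay, with a stated time of 48 h; on this read-out lower numbers stand for higher toxicity in this test and higher numbers for lower toxicity in this test:

Compound 1 `O=C(Nc1cccc(-n2cc(-c3ccncc3)c(-c3ccc(Cl)c(O)c3)n2)c1)Nc1cccc(C(F)(F)F)c1`: > 32500 nM, a limit
Compound 2 `COc1cc(-c2nn(-c3cccc(NC(=O)Nc4cc(C(F)(F)F)cc(C(F)(F)F)c4)c3)cc2-c2ccncc2)ccc1Cl`: 18000 nM
Compound 3 `COc1cc(-c2nn(-c3cccc(NC(=O)c4cccc(C(F)(F)F)c4)c3)cc2-c2ccncc2)ccc1Cl`: > 50000 nM, a limit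

Of these three, only compound 2 gives a number, 18000 nM. Compound 3 stands at the limit of the test, and its > 50000 nM is a limit and not a number. The account now turns to compound 4 `COc1cc(-c2nn(-c3cccc(NC(=O)c4ccccc4)c3)cc2-c2ccncc2)ccc1Cl`, which has hydrogen in place of trifluoromethyl on an aromatic carbon, meta to a large group: hydrogen in place of trifluoromethyl on an aromatic carbon.

No measured pair among these compounds shows this change on its own, so what follows is an expectation only. In this assay, no step beyond the scatter is expected, in either direction, and a further limit rather than a number is the likeliest report. The estimated change is a number no higher from compound 3 to compound 4 (the limit leaves the size open). The expected value for compound 4 is 50000 nM, with an estimated range from 22000 nM to 100000 nM.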

Compound 4, concentration lethal to 50% of the cells: > 100000 nM
Compound 4 ended at the assay's limit; the forecaster's own chance of this, stated with the estimate: 75%; middle value at least 2.0-fold (0.30 log units) away from the limit.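

In this assay, compound 3 and compound 4 are both reported as limits and not as numbers, and the step between them, hydrogen in place of trifluoromethyl, cannot be read. The compounds shown leave open whether this change shifts the value at all, and by how much.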